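Aryl swap on the ring amine nitrogen: compound 4

The source may report more compounds than this note shows. Statements on the series, on what has been measured and on what is new or still open speak of the compounds shown alone.

Measured so far:
compound 1 `S=c1oc(-c2ccc3c(c2)OCCO3)nn1CN1CCN(c2cccc(Cl)c2Cl)CC1`: > 50000 nM
compound 2 `S=c1oc(-c2ccc3c(c2)OCCO3)nn1CN1CCN(c2ccccc2)CC1`: > 50000 nM
compound 3 `COc1ccccc1N1CCN(Cn2nc(-c3ccc4c(c3)OCCO4)oc2=S)CC1`: 15500 nM

In a functional assay on HepG2 cells (Homo sapiens) for antiproliferative activity, read by MTT assay, with a stated time of 48 h (on this read-out lower numbers stand for stronger inhibition and higher numbers for weaker inhibition), compound 1 gives only a limit, > 50000 nM. Compound 2 likewise gives only a limit, > 50000 nM. Among the measured compounds shown here, compound 3 is the single compound with a number, 15500 nM, and so stands as the only readable point in the set; the rest sit at the limit of > 50000 nM in this assay, at which 2 of the 3 values shown sit.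

The two readable steps both end at compound 3: an at least 3.2-fold lower number from compound 1 to compound 3 (0.50 log units; beyond the scatter) and an at least 3.2-fold lower number from compound 2 to compound 3 (0.50 log units; beyond the scatter). The step that the two limits leave unreadable from compound 1 to compound 2 cannot be sized.

Compound 4 `O=[N+]([O-])c1ccc(N2CCN(Cn3nc(-c4ccc5c(c4)OCCO5)oc3=S)CC2)cc1` differs from compound 3 as follows: 4-nitrophenyl in place of 2-methoxyphenyl on an amine nitrogen in a ring. For the measured compounds named here, no measured step puts a nitro group on this aryl ring. What the measured steps show is that the 2-methoxyphenyl of compound 3 is the one arrangement that gave a number, and that phenyl and 2,3-dichlorophenyl at the same nitrogen gave only limits. The change to 4-nitrophenyl removes the methoxy that separates compound 3 from compound 2, so a rise toward the limit is the expectation, a 2.6-fold higher number from compound 3 to compound 4 (0.41 log units; beyond the scatter).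

Compound 4 is therefore estimated at 40000 nM, with a range of 12000 nM to 120000 nM, and a fair chance that only a limit is reported.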

Compound 4, half-maximal inhibitory concentration: 29500 nM
For compound 4 the middle estimate is 1.4-fold (0.13 log units) above the measured one; low and high end bracket the measured number.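

In this assay, compound 4 gives a second readable number, so the 2-methoxyphenyl of compound 3 is no longer the only aryl group on this amine nitrogen to come in under the limit: the limit of > 50000 nM in this assay, at which 2 of the 4 values shown sit.

Exchanging the two aryl groups is a 1.9-fold higher number from compound 3 to compound 4 (0.28 log units; within the scatter), so 4-nitrophenyl and 2-methoxyphenyl are not told apart at this position. The separation from the two limited compounds is less secure for the nitro compound: nitro in place of hydrogen gives an at least 1.6-fold lower number from compound 2 to compound 4 (0.22 log units; that floor lies within the scatter), and 4-nitrophenyl in place of 2,3-dichlorophenyl gives an at least 1.6-fold lower number from compound 1 to compound 4 (0.22 log units; that floor lies within the scatter), whereas the corresponding floors for compound 3 lie beyond the scatter.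

The step between compound 1 and compound 2 cannot be read, and the compounds shown do not settle whether phenyl and 2,3-dichlorophenyl truly differ from each other or from the two readable aryl groups. Also open, from the compounds shown here alone, is how this position responds to an amine or a carboxylic acid on the aryl ring, or to a longer chain between the ring nitrogen and that ring.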